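The source may report more compounds than this note shows. Statements on the series, on what has been measured and on what is new or still open speak of the compounds shown alone.

Measured in a functional assay on PC-3 cells (Homo sapiens) for cytotoxicity, read by MTT assay, with a stated time of 48 h; a lower number here means a stronger inhibitor, a higher number a weaker inhibitor:
- Compound 1 `COc1ccc(-c2cn(C(=O)Nc3cc(OC)c(OC)c(OC)c3)c(=O)n2-c2cc(OC)c(OC)c(OC)c2)cc1OC`: > 50000 nM, a limit of the assay
- Compound 2 `COc1ccc(-c2cn(C(=O)Nc3cc(OC)c(OC)c(OC)c3)c(=O)n2-c2cc(OC)c(OC)c(OC)c2)cc1N`: 10000 nM

Among the measured compounds shown here, compound 2 holds the only actual number so far, since the other result is a limit. Compound 3 `COc1ccc(-c2cn(C(=O)Nc3cc(OC)c(OC)c(OC)c3)c(=O)n2-c2cc(OC)c(OC)c(OC)c2)cc1O` carries hydroxy in place of amino on an aromatic carbon, ortho to a methoxy group: hydroxy in place of amino on an aromatic carbon. For the measured compounds named here, one measured step bears on this place, an at least 5.0-fold lower number from compound 1 to compound 2 (0.69 log units; beyond the scatter), at least modest and beyond the scatter. It exchanges methoxy for amino, so it gives no direct measure of hydroxy. The expected change is a 1.2-fold higher number from compound 2 to compound 3 (0.08 log units; within the scatter), with no step beyond the scatter expected in this assay. Compound 3 is estimated at 12000 nM, with an expected range of 3000 nM to 50000 nM.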

Compound 3, half-maximal inhibitory concentration: > 50000 nM
Compound 3 was reported as a limit; the forecaster's own chance of this, stated with the estimate: 25%; middle value at least 4.1-fold (0.61 log units) from the limit.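

In this assay, hydroxy in place of amino on this aromatic carbon gives an at least 5.0-fold higher number from compound 2 to compound 3 (0.69 log units; beyond the scatter), so a measurable value here goes with the amino group and not with just any exchange of the methoxy group for a hydrogen-bond donor. Compound 3 stands at a limit of the assay, > 50000 nM. The step between compound 1 and compound 3 cannot be read, since both results are limits: the limit of > 50000 nM in this assay, at which 2 of the 3 values shown sit.

As far as these compounds go, it remains open whether a methylamino, dimethylamino or acetamido group at this place would keep a measurable value. From the compounds shown here alone, how far the value of compound 3 lies past its limit also remains open.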